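The source may report more compounds than this note shows. Statements on the series, on what has been measured and on what is new or still open speak of the compounds shown alone.

Series notes. The shared core carries a 4-hydroxyphenyl group and a 2-chlorophenyl group; the third aryl group varies. For compound 1 `Oc1ccc(-c2cc(-c3cccnc3)nc(-c3ccccc3Cl)c2)cc1` the entry in a functional assay on T47D cells (Homo sapiens) for cytotoxicity, read by CCK-8 assay and cell counting, with a stated time of 2 days (on this read-out lower numbers stand for stronger inhibition and higher numbers for weaker inhibition), reads "not determined" (no result reported), so compound 1 has no result there. Within the data shown here, compound 2 `Oc1ccc(-c2cc(-c3ccccc3)nc(-c3ccccc3Cl)c2)cc1` gives 5460 nM in this assay, and that is the only number in hand, so compound 2 stands alone in this assay with nothing to rank it against. Compound 3 `Oc1ccc(-c2cc(-c3cccs3)nc(-c3ccccc3Cl)c2)cc1` differs from compound 2 by thiophen-2-yl in place of phenyl on an aromatic carbon. Among the measured compounds shown here, no step between two measured compounds is available to calibrate this change, so the expectation rests on the single value of compound 2 and on the change being a swap of one aromatic ring for another of similar size. The step is expected to be small, none beyond the scatter in either direction, giving a 1.2-fold lower number from compound 2 to compound 3 (0.08 log units; within the scatter). Compound 3 is therefore estimated at 4500 nM in this assay, with a range from 1500 nM to 15000 nM.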

Compound 3, half-maximal inhibitory concentration: 5870 nM
The estimate for compound 3 lay 1.3-fold (0.12 log units) below the measured number; measured number inside the range.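

In this assay, thiophen-2-yl in place of phenyl on the aromatic carbon next to the ring nitrogen gives a 1.1-fold higher number from compound 2 to compound 3 (0.03 log units; within the scatter), so compound 2 and compound 3 cannot be told apart. Among these compounds, this is the first step available, and it shows that at this position a five-membered aromatic ring with a sulfur atom can stand in for the six-membered carbon ring with no change beyond the scatter. No measured evidence bearing on this result is available.

Compound 1 has no number, so its steps to compound 2 and compound 3 cannot be read. Still open, going by these compounds, is whether a group other than an aromatic ring at this position, such as an amine or a longer alkyl chain, would move the number beyond the scatter, and how a methoxy group in place of the hydroxyl of the 4-hydroxyphenyl group would read.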